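Shared-core series: terminal amide replacement, compound 2 to 4

The source may hold more compounds than are shown below. What is called first, only, known or untested is meant among the compounds shown, and "the series" means these compounds.

Measured so far in an assay on HEK293 cells for displacement of a labelled ligand from NPC1-like intracellular cholesterol transporter 1 (Homo sapiens); a higher number here means a weaker inhibitor, a lower number a stronger inhibitor:
compound 1 `CC(C)(C)OC(=O)NCCNC(=O)CN1CN(c2ccccc2)C2(CCN(C(=O)c3ccc(C(C)(C)C)cc3)CC2)C1=O`: 10900 nM
compound 2 `CC(C)(C)OC(=O)NCCNC(=O)CN1CN(c2ccccc2)C2(CCN(C(=O)c3ccc(C4CCCCC4)cc3)CC2)C1=O`: 5500 nM
compound 3 `CC(C)(C)c1ccc(C(=O)N2CCC3(CC2)C(=O)N(CC(=O)NCCCN)CN3c2ccccc2)cc1`: 4200 nM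

Compound 2 stands second highest of the three numbers in this assay; its nearest neighbour is compound 3, within the scatter, and its furthest is compound 1, also within the scatter (a 2.0-fold lower number from compound 1 to compound 2 (0.30 log units; within the scatter)). Compound 4 `CCOC(=O)C1CCCN(C(=O)CN2CN(c3ccccc3)C3(CCN(C(=O)c4ccc(C5CCCCC5)cc4)CC3)C2=O)C1` differs from compound 2 at the amide end: 3-(ethoxycarbonyl)piperidin-1-yl in place of (2-((tert-butoxycarbonyl)amino)ethyl)amino on a carbonyl carbon. Among the measured compounds shown here, no measured step makes this exact change. For the measured compounds named here, the one step touching the same chain end is a 2.6-fold lower number from compound 1 to compound 3 (0.41 log units; beyond the scatter), a modest gain, and the step of a 2.0-fold lower number from compound 1 to compound 2 (0.30 log units; within the scatter) at the aromatic carbon is already built into compound 2. Going by the values given here, with no direct precedent, a step from compound 2 to compound 4 of no more than a 1.2-fold lower number from compound 2 to compound 4 (0.09 log units; within the scatter) is expected, without clear direction. Compound 4 is therefore estimated at 4500 nM, with a range of 1500 nM to 14000 nM.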

Compound 4, half-maximal inhibitory concentration: 4200 nM
The estimate for compound 4 lay 1.1-fold (0.03 log units) above the measured number; the measured number falls inside the stated range.
By their numbers in this assay, from the lowest: compounds 3, 4, 2 and 1 (each within the scatter of the next, the first and the last beyond it).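

In this assay, the carbonyl carbon accepts 3-(ethoxycarbonyl)piperidin-1-yl in place of (2-((tert-butoxycarbonyl)amino)ethyl)amino, with a 1.3-fold lower number from compound 2 to compound 4 (0.12 log units; within the scatter). The entering group has no hydrogen-bond donors and brings a six-membered non-aromatic ring, yet the step stays within the scatter, so neither feature registers as a change in this pair. No supporting measurement bears on this result.

Still open, on these data alone, is whether a carboxylic acid or a primary amine in place of the ethoxycarbonyl group would shift the number. Also open, as far as these compounds go, is whether the same exchange reads alike with tert-butyl on the aromatic carbon.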